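The compounds below may be only part of what the source reports. "The series", "measured", "known", "first", "only" and "open" are said of these compounds alone.

Measured so far in a functional assay on MCF7 cells (Homo sapiens) for cytotoxicity, read by MTT assay, with a stated time of 2 days, tested at 1 uM; a higher number here means a weaker effect of the compound at the concentration tested, a lower number a stronger effect:

compound 1, `CC(=O)c1cc(-c2ccccc2)cc2cc(-c3ccccc3)[nH]c12`, gives 98.6%
compound 2, `CC(=O)c1cc(-c2ccccc2)cc2cc(-c3ccc(F)cc3)[nH]c12`, gives 96.8%
compound 3, `COc1ccc(-c2cc3cc(-c4ccccc4)cc(C(C)=O)c3[nH]2)cc1`, gives 78.1%

Compound 3 has the lowest number of the three. The unmeasured compound 4 is `COc1ccc(-c2cc3cc(-c4ccc(F)cc4)cc(C(C)=O)c3[nH]2)cc1`. Its change from compound 3 is fluoro in place of hydrogen on an aromatic carbon. The same change has been made once before, from compound 1 to compound 2: fluoro in place of hydrogen on an aromatic carbon, and there it made a step of a number 1.8 percentage points lower from compound 1 to compound 2 (within the scatter), within the scatter. The two cores differ by methoxy in place of hydrogen on an aromatic carbon, and the place of the fluoro is described in the same words in both cases, so this is the same kind of change on a different core. Resting on the small step from compound 1 to compound 2 in this assay, compound 4 is expected to sit close to compound 3, with an estimated step of a number 2.1 percentage points lower from compound 3 to compound 4 (within the scatter). Compound 4 is estimated at 76%, between 63% and 89%.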

Compound 4, a percentage reported as activity, at one concentration (the size of the read-out at that concentration, not a potency): 96.4%
Beside the measured number, compound 4's estimate is 20.4 percentage points below it, outside the stated range (above it).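

On the core carrying the methoxy, fluoro in place of hydrogen made a step of a number 18.3 percentage points higher from compound 3 to compound 4 (beyond the scatter), which means a weaker effect at the concentration tested. Set beside the earlier case, the same change did not carry over from one core to the other in this assay: the same change on two cores in this assay, a number 1.8 percentage points lower (within the scatter) from compound 1 to compound 2 and a number 18.3 percentage points higher (beyond the scatter) from compound 3 to compound 4, 20.1 percentage points apart, beyond the scatter of two such steps So what phenyl to 4-fluorophenyl does here depends on the core, but a single pair on each core cannot show why, or how this would play out on any other core.

The compounds shown leave open whether chloro or an amine at the same place would also behave differently on the two cores. They also leave open whether ethoxy in place of methoxy would do the same.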